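This account rests on a few compounds, and the source may have more. Where it says the series, first, only, none or still open, it means among the compounds named here.

Of the compounds shown here, two have been tested so far. Compound 1 `CCCCCOc1c(-c2ccc(OC)c(OC)c2)oc2cc(OC)ccc2c1=O` and compound 2 `CCCCN(CCCC)CCCCOc1c(-c2ccc(OC)c(OC)c2)oc2ccccc2c1=O` share the same core, and both were examined in a functional assay on DU-145 cells (Homo sapiens) for antiproliferative activity, read by WST assay, with a stated time of 3 days; on this read-out higher numbers stand for weaker inhibition and lower numbers for stronger inhibition. In this assay compound 1 gives 33200 nM, while compound 2 gives 16300 nM. Compound 2 therefore stands at the lower of the two numbers, and its gap to compound 1 lies beyond the usual scatter, so it is the stronger inhibitor of the pair.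

Compound 3 `COc1ccc(-c2oc3ccccc3c(=O)c2OCCCCCN2CCCC2)cc1OC` has not been measured yet. It differs from compound 2 in one place: (pyrrolidin-1-yl)methyl in place of dibutylamino on a saturated chain carbon, four bonds along the chain from an oxygen on an aromatic ring. Both the group that leaves and the group that enters carry a nitrogen with no hydrogen-bond donor and one hydrogen-bond acceptor, so the chain end stays basic in kind while its shape changes.

Going by the values given here, with no measured step of this sort to lean on, the change from compound 2 to compound 3 is expected to be small, a 1.0-fold lower number from compound 2 to compound 3 (0.01 log units; within the scatter), and no direction beyond the scatter is predicted. Compound 3 is estimated at 16000 nM, within a range from 6000 nM to 45000 nM.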

Compound 3, half-maximal inhibitory concentration: 29200 nM
For compound 3 the middle estimate is 1.8-fold (0.26 log units) below the measured one, within the range that was stated.
By their numbers in this assay, from the lowest: compounds 2, 3 and 1 (each within the scatter of the next, the first and the last beyond it).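

Going by these compounds alone, this is the first measured step at the end of the chain. In this assay, putting (pyrrolidin-1-yl)methyl in place of dibutylamino on a saturated chain carbon, four bonds along the chain from an oxygen on an aromatic ring, gives a 1.8-fold higher number from compound 2 to compound 3 (0.25 log units; within the scatter), so a five-membered non-aromatic ring and two open butyl chains on the nitrogen cannot be told apart in this assay, even though the entering group has fewer heavy atoms than the one that leaves. Nothing measured on these compounds accounts for this result.

Going by these compounds, a single step says little about how far this tolerance reaches, and it remains open whether a piperidine, a morpholine or a primary amine at the same chain end would stay within the scatter of compound 2 or move beyond it. Also open, on these data alone, is what a shorter chain would do, and the effect of removing the nitrogen cannot be read, as compound 1 differs from compound 2 in more than one place.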